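The source may hold more compounds than are shown below. What is called first, only, known or untested is meant among the compounds shown, and "the series" means these compounds.

Working notes on the series, measured in a functional assay on HeLa cells (Homo sapiens) for cytotoxicity, read by sulforhodamine B assay, with a stated time of 48 h; on this read-out higher numbers stand for weaker inhibition and lower numbers for stronger inhibition. Compound 1 `O=c1cc(-c2ccccc2)oc2cc(OCCCCNc3nc4ccc(Cl)cc4s3)cc(O)c12` gives 5.95 ug/mL in this assay. Compound 2 `O=c1cc(-c2ccccc2)oc2cc(OCCCCNc3nc4ccc(I)cc4s3)cc(O)c12` gives 8.12 ug/mL in this assay, and compound 3 `O=c1cc(-c2ccccc2)oc2cc(OCCCCNc3nc4ccc(C(F)(F)F)cc4s3)cc(O)c12` gives 7.84 ug/mL. Among the measured compounds shown here, compound 2 has the highest of the three numbers as they stand, yet no step separates it from the others beyond the scatter: a 1.4-fold higher number from compound 1 to compound 2 (0.14 log units; within the scatter), a 1.3-fold higher number from compound 1 to compound 3 (0.12 log units; within the scatter), and a 1.0-fold lower number from compound 2 to compound 3 (0.02 log units; within the scatter). Each of those steps swaps one group on an aromatic carbon and none of them moves the number in this assay beyond the scatter.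

The next compound, compound 4 `O=c1cc(-c2ccccc2)oc2cc(OCCCCNNc3nc4ccccc4s3)cc(O)c12`, differs from compound 2 by (1,3-benzothiazol-2-yl)amino in place of 6-iodo-1,3-benzothiazol-2-yl on an amine nitrogen. For the measured compounds named here, no measured step touches the amine nitrogen or the saturated chain carbon beside it; the three measured steps only exchange groups on the aromatic carbon, and each was within the scatter. They therefore give no ground to expect a step in this assay beyond the scatter, but they also say nothing direct about this change, so the range is kept wide. The expected step is a 1.0-fold lower number from compound 2 to compound 4 (0.01 log units; within the scatter). Compound 4 is estimated at 8 ug/mL, with a range from 4 ug/mL to 16 ug/mL.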

Compound 4, half-maximal inhibitory concentration: 4.64 ug/mL
Compound 4: the middle estimate sits 1.7-fold (0.24 log units) above what was measured; the measured number falls inside the stated range.
By their numbers in this assay, from the lowest: compounds 4, 1, 3 and 2 (each within the scatter of the next).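

In this assay the exchange on the amine nitrogen gives a 1.8-fold lower number from compound 2 to compound 4 (0.24 log units; within the scatter) and, measured against the chloro member of the series, a 1.3-fold lower number from compound 1 to compound 4 (0.11 log units; within the scatter) for the corresponding exchange. Among the compounds shown here, these are the first readings at this position, which the earlier steps on the aromatic carbon did not touch, and like those steps they stay within the scatter. Each of the two steps combines the loss of the halogen with the entry of a further amine nitrogen, so neither change is read alone here, and the result says only that the two together do not separate compound 4 from compound 1 or compound 2.

Still open, as far as these compounds go, is how the added amino link behaves when chloro or iodo stays on the 1,3-benzothiazol-2-yl group, and how the unsubstituted 1,3-benzothiazol-2-yl group behaves on the amine nitrogen without that link. Also open, from the compounds shown here alone, is whether a longer chain, or a carboxylic acid or methoxy on the aromatic carbon, would move the number beyond the scatter. No measurement on hand offers an explanation for these readings.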